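A few compounds are considered here, and "the series" means these few. Any claim that something is new, unique, unknown or untested is made for them only; others in the source may bear on it.

Compound 1 `CC(C)=CC(=O)Nc1c(C(O)(C(F)(F)F)C(F)(F)F)ccc2ccccc12` and compound 2 `O=C(Nc1c(C(O)(C(F)(F)F)C(F)(F)F)ccc2ccccc12)c1cccc(Cl)c1` share one core and differ only in the group attached to the carbonyl carbon of the amide. In a functional assay (Sus scrofa) with sulfonylurea receptors; K-ATP channels (Homo sapiens) as the target (a higher number here means that more compound is needed for the effect, a lower number that less compound is needed), compound 1 gives 550 nM, and in this assay compound 2 gives 851 nM. The measured step of a 1.5-fold higher number from compound 1 to compound 2 (0.19 log units; within the scatter) shows that this exchange left the read-out essentially unchanged. Compound 2 therefore stands with the higher of the two numbers, but its nearest neighbour, compound 1, lies within the scatter of it, so no order between the two can be claimed.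

Compound 3 `Cc1cccc(C(=O)Nc2c(C(O)(C(F)(F)F)C(F)(F)F)ccc3ccccc23)c1` differs from compound 2 by methyl in place of chloro on an aromatic carbon. Among the compounds with values here, only one measured step exists, and it concerns the whole group on the carbonyl carbon rather than a single substituent on the aromatic ring, so nothing measured bears directly on the exchange of chloro for methyl. Within the data shown here, with the one available step lying within the scatter, the expected step is a 1.1-fold lower number from compound 2 to compound 3 (0.03 log units; within the scatter), that is, no change beyond the scatter. Compound 3 is thus expected to give about 800 nM in this assay, with an estimated range from 350 nM to 1900 nM.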

Compound 3, half-maximal effective concentration: 52.5 nM
Compound 3: the middle estimate sits 15-fold (1.18 log units) above what was measured; measured number below the stated range.
By their numbers in this assay, from the lowest: compound 3; then compounds 1 and 2 (each within the scatter of the next).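

In this assay, the aromatic carbon that carries chloro in compound 2, meta to a large group, proves far more sensitive than the earlier pair suggested: methyl in place of chloro gives a 16-fold lower number from compound 2 to compound 3 (1.21 log units; beyond the scatter) even though the heavy-atom count and the hydrogen-bond donor and acceptor counts stay the same. The group on the carbonyl carbon can therefore no longer be treated as freely exchangeable, since 3-methylphenyl in place of 2-methylprop-1-en-1-yl gives a 10-fold lower number from compound 1 to compound 3 (1.02 log units; beyond the scatter) while the same exchange with 3-chlorophenyl stayed within the scatter. The outcome of replacing that group thus depends on the single substituent on the aromatic ring, and compound 3 has the lowest number of the three, with both of its steps beyond the scatter.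

With only chloro and methyl shown at this place, it remains open whether ethyl, methoxy, fluoro or an amine would give a number nearer that of compound 3 or that of compound 2, and whether methyl would have the same effect on another carbon of the ring. Nothing available explains why methyl and chloro differ so strongly here.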